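The source may report more compounds than this note shows. Statements on the series, on what has been measured and on what is new or still open speak of the compounds shown alone.

In an ADME assay on HEL cells (Homo sapiens) for cytotoxicity, with a stated time of 3 days (on this read-out lower numbers stand for higher toxicity in this test and higher numbers for lower toxicity in this test), compound 2 `CCC1(Cc2ccccc2)OS(=O)(=O)C=C1OC` gives > 400000 nM, which is a limit of the assay and not a number. Compound 1 `CCC1(Cc2ccccc2)OS(=O)(=O)C=C1OCC(=O)OC` also reaches only a limit, > 400000 nM, in this assay. Compound 3 `CCC1(Cc2ccccc2)OS(=O)(=O)C=C1OCc1ccccc1Cl` gives >= 20000 nM in this assay, again a limit rather than a number. Of the three values shown, two sit at the limit of > 400000 nM in this assay, at which 2 of the 3 values shown sit, and one at the limit of >= 20000 nM in this assay, at which 1 of the 3 values shown sits, and compound 2 sits at the first of these. Compound 4 `CCC1(Cc2ccccc2)OS(=O)(=O)C=C1NCc1ccccc1` has not yet been measured and differs from compound 2 by benzylamino in place of methoxy on a double-bonded ring carbon. The measured step that comes nearest to this change is a step that the two limits leave unreadable from compound 2 to compound 3, and the steps a step that the two limits leave unreadable from compound 1 to compound 2 and a step that the two limits leave unreadable from compound 1 to compound 3 are likewise unreadable, so none of them gives a readable size or direction. With no readable step to lean on, no change beyond the scatter is expected for compound 4, and a further limit is likely. Compound 4 is therefore expected to give 300000 nM, within 50000 nM to 400000 nM, in this assay. The step so expected from compound 2 to compound 4 is an at least 1.3-fold lower number from compound 2 to compound 4 (0.12 log units; that floor lies within the scatter).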

Compound 4, minimum cytotoxic concentration: >= 80000 nM
Compound 4 gave a limit, no number; the forecaster's own chance of this, stated with the estimate: 70%; the middle value lies beyond the limit too.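

Compound 4 gives only a limit, as do compound 1 and compound 2, so the steps from compound 1 and compound 2 to compound 4 cannot be read. The compounds shown leave open whether benzylamino in place of methoxy changes the minimum cytotoxic concentration at all, and in which direction.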